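A few compounds are considered here, and "the series" means these few. Any claim that something is new, unique, unknown or untested is made for them only; others in the source may bear on it.

Compound 1 `CC(C)(C)N(NC(=O)c1ccccc1)C(=O)c1ccccc1C(F)(F)F` and compound 2 `Cc1ccccc1C(=O)NN(C(=O)c1ccccc1Cl)C(C)(C)C` share a common core and differ only in the groups on their two aromatic rings. In an assay on cells for agonist activity at ecdysone receptor (Bombyx mori), read by a luciferase reporter, with a stated time of 24 h (a lower number here means that less compound is needed, a higher number that more compound is needed for the effect), compound 1 gives 631 nM, while compound 2 gives 72.4 nM, the lowest of the two numbers; its gap to compound 1 lies beyond the usual scatter. Compound 3 `Cc1ccc(C)c(C(=O)NN(C(=O)c2ccccc2Cl)C(C)(C)C)c1` is not yet measured. It differs from compound 2 by methyl in place of hydrogen on an aromatic carbon. For the measured compounds named here, with no measured pair of this kind to lean on, the expected step is a 1.4-fold lower number from compound 2 to compound 3 (0.16 log units; within the scatter), a small move toward a lower number in this assay. Compound 3 is estimated at 50 nM, with a likely range from 15 nM to 200 nM.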

Compound 3, half-maximal effective concentration: 1620 nM
Compound 3: the middle estimate sits 32-fold (1.51 log units) below what was measured; the whole stated range lies below it.
By their numbers in this assay, from the lowest: compound 2; then compound 1; then compound 3.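

Adding a single methyl at this place, turning 2-methylphenyl into 2,5-dimethylphenyl, is not a minor change: in this assay it gives a 22-fold higher number from compound 2 to compound 3 (1.35 log units; beyond the scatter). At this position, meta to a large group and para to a methyl group, one added carbon is enough to make far more compound necessary for the effect. No measurement here shows why the number rises. On these data alone, whether a smaller fluorine atom, a methoxy group or an amine in the same place would cost as much remains open.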